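This account rests on a few compounds, and the source may have more. Where it says the series, first, only, none or still open, it means among the compounds named here.

Compound 1 `CCC(=O)c1cc(-c2ccc(S(N)(=O)=O)cc2)n(-c2ccc(Cl)cc2)n1`: 41900 nM
Compound 2 `CCC(=O)c1cc(-c2ccc(S(N)(=O)=O)cc2)n(-c2ccc(OC)cc2)n1`: 64300 nM
Compound 3 `CCC(=O)c1cc(-c2ccc(S(N)(=O)=O)cc2)n(-c2ccc(Cl)cn2)n1`: 33700 nM

These three compounds share one core and have all been measured in a physicochemical assay for solubility, read by HPLC, in phosphate buffer, measured as kinetic solubility, at pH 7.4; a higher number here means a more soluble compound, a lower number a less soluble compound. On the numbers shown, compound 1 stands second highest of the three; its nearest neighbour is compound 3, with a 1.2-fold lower number from compound 1 to compound 3 (0.09 log units; within the scatter), and its furthest is compound 2, with a 1.5-fold higher number from compound 1 to compound 2 (0.19 log units; within the scatter). The remaining pair gives a 1.9-fold lower number from compound 2 to compound 3 (0.28 log units; within the scatter). Every one of these steps lies within the scatter, so the three values cannot be told apart.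

Compound 4 `NS(=O)(=O)c1ccc(-c2cc(C(=O)N3CC4CC4C3)nn2-c2ccc(Cl)cc2)cc1` has not yet been measured. It differs from compound 1 in one place: a group of 6 heavy atoms (5 carbon, 1 nitrogen; one three-membered non-aromatic ring of carbon only, one five-membered non-aromatic ring with 1 hetero atom) in place of a group of 2 heavy atoms (2 carbon; no ring), on a carbonyl carbon

Going by the values given here, none of the measured steps bears on this change. Each of them swaps a group on an aromatic carbon or on an aromatic nitrogen, and none touches the carbonyl carbon, so they give no guide to what a larger replacement there will do. The expectation therefore rests on compound 1 alone, because compound 1 gives 41900 nM, with room left for a modest shift in either direction. Compound 4 is expected to give about 20000 nM, in a range from 6000 nM to 55000 nM. That estimate means an expected 2.1-fold lower number from compound 1 to compound 4 (0.32 log units; beyond the scatter).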

Compound 4, solubility: 36600 nM
Estimate against measurement, compound 4: 1.8-fold (0.26 log units) below; measured number inside the range.
By their numbers in this assay, from the lowest: compounds 3, 4, 1 and 2 (each within the scatter of the next).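

Going by these compounds alone, the earlier compounds differ only in groups on an aromatic carbon or an aromatic nitrogen, so compound 4 gives the first reading at the carbonyl carbon. In this assay, placing the group of 6 heavy atoms, with its three-membered ring of carbon only and its five-membered ring with 1 hetero atom, where ethyl stood gives a 1.1-fold lower number from compound 1 to compound 4 (0.06 log units; within the scatter) and this step lies within the scatter. On this single pair, then, a much larger group with two rings on the carbonyl carbon gives a number that cannot be told apart from the number given with ethyl. Nothing measured here offers an explanation for this result.

One replacement says little about the position as a whole, and the compounds shown leave open whether a longer chain such as butyl, a carboxylic acid or a morpholine on the carbonyl carbon would move the number beyond the scatter. They also leave open whether the same change gives a similar step with 4-methoxyphenyl or 5-chloropyridin-2-yl in place of 4-chlorophenyl on the aromatic nitrogen.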